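Methyl on the Amide Nitrogen of Compound 1

The source may hold more compounds than are shown below. What is called first, only, known or untested is meant among the compounds shown, and "the series" means these compounds.

Among the compounds with values here, compound 1 `Cc1ccc(-c2nn(C(C)C)cc2C(=O)Nc2ccc(C)c(S(=O)(=O)N3CCOCC3)c2)cc1` gives 1690 nM in an assay on HEK-293T cells for inhibition of Bile acid receptor (Homo sapiens), read by a beta-lactamase reporter, with a stated time of 16 h (a lower number here means a stronger inhibitor, a higher number a weaker inhibitor), the lowest of the two numbers measured so far; compound 2 `COc1cccc(-c2nn(C(C)C)cc2C(=O)Nc2ccc(C)c(S(=O)(=O)N3CCOCC3)c2)c1` gives 3490 nM. Within the data shown here, the only step within the measured pair, a 2.1-fold higher number from compound 1 to compound 2 (0.31 log units; beyond the scatter), concerns the aryl substituent and is modest. Compound 3 `Cc1ccc(-c2nn(C(C)C)cc2C(=O)N(C)c2ccc(C)c(S(=O)(=O)N3CCOCC3)c2)cc1` differs from compound 1 by methyl in place of hydrogen on an amide-type nitrogen. Among the measured compounds shown here, no measured step touches the amide nitrogen, so nothing shows directly how this assay answers such a change; the one measured step, at a different place in the molecule, offers only a sense of scale. Compound 3 is expected to give a higher number than its parent, the step estimated as a 3.0-fold higher number from compound 1 to compound 3 (0.47 log units; beyond the scatter), with wide uncertainty in either direction. The estimate for compound 3 in this assay is 5000 nM, within a range from 1500 nM to 20000 nM.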

Compound 3, half-maximal inhibitory concentration: 16200 nM
Compound 3: the middle estimate sits 3.2-fold (0.51 log units) below what was measured; measured number inside the range.
By their numbers in this assay, from the lowest: compound 1; then compound 2; then compound 3.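

The amide nitrogen of compound 1 is clearly sensitive to substitution: in this assay, methyl in place of the amide hydrogen gives a marked rise in the number (a 9.6-fold higher number from compound 1 to compound 3 (0.98 log units; beyond the scatter)). This step is larger than the one at the aryl substituent (a 2.1-fold higher number from compound 1 to compound 2 (0.31 log units; beyond the scatter)), so of the two places changed in these three compounds, the amide nitrogen shows the greater response. Nothing measured here bears on the reason for this rise.

With methyl as the only replacement, a response specific to methyl cannot be separated from a response to any loss of the amide hydrogen; ethyl or a longer chain on that nitrogen would address this. Going by these compounds, whether the methyl step carries over to the 3-methoxyphenyl compound 2 also remains open.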